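The compounds below may be only part of what the source reports. "The series", "measured", "known", "first", "only" and "open" are said of these compounds alone.

- Compound 1 `CN1CCN(c2ccc(-c3cc4c(N5CCN(C(=O)Nc6ccccc6)CC5)ncnc4s3)cc2)CC1`: 7590 nM
- Compound 2 `COc1ccc(NC(=O)N2CCN(c3ncnc4sc(-c5ccc(N6CCN(C)CC6)cc5)cc34)CC2)cc1`: 20900 nM
- Compound 3 `CN1CCN(c2ccc(-c3cc4c(N5CCN(C(=O)Nc6ccc(F)cc6F)CC5)ncnc4s3)cc2)CC1`: 11400 nM

In a functional assay on MDA-MB-231 cells (Homo sapiens) for antiproliferative activity, read by MTT assay, with a stated time of 48 h (a higher number here means a weaker inhibitor, a lower number a stronger inhibitor), compound 3 at 11400 nM lies within the scatter of both other compounds, as shown by a 1.5-fold higher number from compound 1 to compound 3 (0.18 log units; within the scatter) and a 1.8-fold lower number from compound 2 to compound 3 (0.26 log units; within the scatter). Only the remaining pair is separated beyond the scatter, by a 2.8-fold higher number from compound 1 to compound 2 (0.44 log units; beyond the scatter).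

Compound 4 `CN1CCN(c2ccc(-c3cc4c(N5CCN(C(=O)Nc6ccc(Cl)c(C(F)(F)F)c6)CC5)ncnc4s3)cc2)CC1` keeps the shared core and carries 4-chloro-3-(trifluoromethyl)phenyl in place of 2,4-difluorophenyl on an amide-type nitrogen.

The three measured steps all change the aromatic group at this same place, and the largest of them is modest. Among the measured compounds shown here, no measured compound carries a chloro or trifluoromethyl group, so the data offer no direct precedent for this change. On that evidence, no step beyond the scatter is expected, and the estimated change is a 1.3-fold lower number from compound 3 to compound 4 (0.10 log units; within the scatter). Compound 4 is estimated at 9000 nM, with an expected range of 3500 nM to 22000 nM.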

Compound 4, half-maximal inhibitory concentration: 2220 nM
Compound 4: the middle estimate sits 4.1-fold (0.61 log units) above what was measured, and the stated range ends above it.
By their numbers in this assay, from the lowest: compound 4; then compounds 1, 3 and 2 (each within the scatter of the next, the first and the last beyond it).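

In this assay the change to 4-chloro-3-(trifluoromethyl)phenyl on the amide-type nitrogen shows a 5.1-fold lower number from compound 3 to compound 4 (0.71 log units; beyond the scatter) and a 3.4-fold lower number from compound 1 to compound 4 (0.53 log units; beyond the scatter) and a 9.4-fold lower number from compound 2 to compound 4 (0.97 log units; beyond the scatter) at this one place. Among the compounds shown here, the earlier groups here gave only one step beyond the scatter, and that step was upward, so this position can also move the number down. For the compounds shown here, compound 4 is the only compound separated beyond the scatter from all the others, and nothing given here explains why this group stands apart.

The compounds shown leave open whether the chloro group alone or the trifluoromethyl group alone would give a similar step. As far as these compounds go, how an amine, a carboxylic acid or a longer chain on this phenyl ring would compare also remains open.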